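Bakuchiol-type phenols at the cytotoxicity limit

This account rests on a few compounds, and the source may have more. Where it says the series, first, only, none or still open, it means among the compounds named here.

Compound 1 `C=C[C@@](C)(/C=C/c1ccc(O)cc1)CC/C=C(C)/C=C/C(=O)OCC`: > 49000 nM (a limit)
Compound 2 `C=C[C@@](C)(/C=C/c1ccc(O)c(C=O)c1)CCC=C(C)C`: > 49000 nM (a limit)

In a functional assay on Jurkat cells (Homo sapiens) for cytotoxicity, with a stated time of 72 h (a lower number here means that less compound is needed, a higher number that more compound is needed for the effect), compound 2 gives > 49000 nM, which is a limit of the assay and not a number. Compound 1 gives > 49000 nM, which is also a limit. Compound 2 therefore stands at the limit of > 49000 nM in this assay, at which 2 of the 2 values shown sit.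

Compound 3 `C=C[C@@](C)(/C=C/c1ccc(O)c(/C=C/C(N)=O)c1)CCC=C(C)C` carries 2-carbamoylethenyl in place of formyl on an aromatic carbon, ortho to a hydroxy group and meta to a large group: 2-carbamoylethenyl in place of formyl on an aromatic carbon. For the measured compounds named here, no measured step covers this change, so any forecast is uncertain, and a result at the same limit remains quite possible. A modest move toward less compound being needed is expected, an estimated at least 1.4-fold lower number from compound 2 to compound 3 (0.14 log units; that floor lies within the scatter). For compound 3 the estimated value is 35000 nM, with an expected range from 10000 nM to 60000 nM.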

Compound 3, half-maximal effective concentration: > 49000 nM
Compound 3: a limit, no number; the forecaster's own chance of this, stated with the estimate: 55%; at least 1.4-fold (0.14 log units) between middle value and limit.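

In this assay, for the compounds shown here, compound 3 gives > 49000 nM as a limit and not a number, so no step from compound 2 to compound 3 can be read. The compounds shown leave open whether any change on the shared core would give a measurable value in this assay at all.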